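The compounds below may be only part of what the source reports. "The series", "measured", "known", "first", "only" and "open" are said of these compounds alone.

Measured compounds:
- compound 1, `Cc1ccc(NC(=O)c2cc(Cl)cc(C(F)(F)F)c2)cc1OC1CCN(C(=O)c2cccnc2)CC1`: in an ADME assay on BaF3 cells (Mus musculus) for antiproliferative activity (on this read-out higher numbers stand for weaker inhibition of growth and lower numbers for stronger inhibition of growth), compound 1 gives > 10000 nM, a limit of the assay.
- compound 2, `Cc1ccc(NC(=O)c2cc(F)cc(C(F)(F)F)c2)cc1OC1CCN(C(=O)c2cccnc2)CC1`: in this assay compound 2 gives > 10000 nM, again a limit of the assay and not a number.

Compound 2 therefore stands at the limit of this assay, and the same holds for compound 1, so that both values shown sit at the limit of > 10000 nM in this assay, at which 2 of the 2 values shown sit. For the measured compounds named here, the single step that connects two measured compounds, from compound 1 to compound 2, is a step that the two limits leave unreadable from compound 1 to compound 2; the two limits leave it unreadable, and it concerns a different part of the molecule in any case.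

Compound 3, `COc1cccc(C(=O)Nc2ccc(C)c(OC3CCN(C(=O)c4cccnc4)CC3)c2)c1`, is not yet measured. It differs from compound 2 by 3-methoxyphenyl in place of 3-fluoro-5-(trifluoromethyl)phenyl on a carbonyl carbon. Going by the values given here, no measured step bears on this change; the only one available is unreadable. With both neighbours at the limit, the step from compound 2 to compound 3 is expected to be a number no higher from compound 2 to compound 3 (the limit leaves the size open), which is no readable step at all. Compound 3 is therefore estimated to give 10000 nM in this assay, within a range of 3000 nM to 30000 nM, most likely reported again as a limit.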

Compound 3, concentration for 50% growth inhibition: > 10000 nM
Compound 3: only a limit was reported (the forecaster's own chance of this, stated with the estimate: 75%); the middle value lies on the limit itself.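

No new step can be read among compound 1, compound 2 and compound 3, since each value is a limit of this assay and not a number: the limit of > 10000 nM in this assay, at which 3 of the 3 values shown sit.

The compounds shown leave open how these three rank against one another, and whether either change on the carbonyl-bearing aryl group alters inhibition of growth at all.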